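Carboxyphenyl exchange at the ether end of compound 2

The source may hold more compounds than are shown below. What is called first, only, known or untested is meant among the compounds shown, and "the series" means these compounds.

Compound 2 `Cc1c(OCCCCOc2ccccc2C(=O)O)ccc(C(=O)CC2CCCC2)c1O` gives 335 nM in an assay on HEK293 cells for positive allosteric modulation of metabotropic glutamate receptor 2 (Rattus norvegicus), read by thallium flux, with a stated time of 2.5 min; a higher number here means that more compound is needed for the effect, a lower number that less compound is needed. Going by the values given here, compound 2 holds the lowest of the two numbers so far: compound 1 `Cc1c(OCCCCOc2ccccc2C(=O)O)ccc(C(=O)CC2CCCC2)c1C` gives 2580 nM, and the step of a 7.7-fold lower number from compound 1 to compound 2 (0.89 log units; beyond the scatter) lies beyond the scatter. For compound 3 `Cc1c(OCCCCOc2ccc(C(=O)O)cc2)ccc(C(=O)CC(C)C)c1C` the result in this assay is "not determined" (no result reported), so the variant with a differently placed carboxy on that ring adds nothing to the numbers.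

The next entry, compound 4 `Cc1ccc(C(=O)O)cc1OCCCCOc1ccc(C(=O)CC2CCCC2)c(O)c1C`, differs from compound 2 in 5-carboxy-2-methylphenyl in place of 2-carboxyphenyl on an oxygen on a saturated carbon. Among the compounds with values here, no measured step bears on this change. Within the data shown here, the only step available, a 7.7-fold lower number from compound 1 to compound 2 (0.89 log units; beyond the scatter), concerns a hydroxy in place of a methyl on an aromatic carbon elsewhere in the molecule and leaves the carboxyphenyl end untouched; compound 3, which does vary that end, has no number. The hydroxy that separates compound 2 from compound 1 is retained in compound 4, so the starting point is the lower number of the two. The size of the change at the carboxyphenyl end cannot be anchored in the data, and the range must stay broad. The expected step is a 1.8-fold higher number from compound 2 to compound 4 (0.25 log units; within the scatter), a shift within or near the scatter rather than a clear move in either direction. Compound 4 is estimated at 600 nM, with a range from 150 nM to 3000 nM.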

Compound 4, half-maximal effective concentration: 1290 nM
Compound 4: middle estimate off by 2.2-fold (0.33 log units), on the low side; the range from low to high includes it.
By their numbers in this assay, from the lowest: compound 2; then compounds 4 and 1 (each within the scatter of the next).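

In this assay, going by these compounds alone, 5-carboxy-2-methylphenyl in place of 2-carboxyphenyl on an oxygen on a saturated carbon gives a 3.9-fold higher number from compound 2 to compound 4 (0.59 log units; beyond the scatter), the only readable step at this end of the molecule, since compound 3 carries no number. The result shows that the number depends on the group at this position even with the hydroxy on the shared core retained, although it rests on this single pair and sets no trend. The entering group differs from the leaving one both in where the carboxy stands and in the added methyl, and no measurement available here accounts for the step.

The compounds shown leave open how the step divides between the moved carboxy and the added methyl, since neither change appears alone. They also leave open whether a tetrazole or an amide in place of the carboxylic acid, or a longer chain between the two ether oxygens, would give a number lower than that of compound 2 at 335 nM.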